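The compounds below may be only part of what the source reports. "The series", "measured", "known", "first", "only" and "open" are said of these compounds alone.

Measured so far:
- Compound 1 `CCCS(=O)(=O)N1CCN(c2ccc(OCC3CCN(C(=O)NC(C)C)CC3)cn2)CC1`; in a functional assay on CHO-K1 cells for agonist activity at Glucose-dependent insulinotropic receptor (Homo sapiens), read by a luciferase reporter, with a stated time of 5 h (a lower number here means that less compound is needed, a higher number that more compound is needed for the effect), compound 1 gives 1000 nM.
- Compound 2 `CCCS(=O)(=O)N1CCN(c2ccc(OCC3CCN(C(=O)NC4CCCCC4)CC3)cn2)CC1`; in this assay compound 2 gives > 10000 nM, which is a limit of the assay and not a number.

Compound 2 thus sits at the edge of what this assay can report, as the limit of > 10000 nM in this assay, at which 1 of the 2 values shown sits, shows. Among the measured compounds shown here, the only measured step is an at least 10-fold higher number from compound 1 to compound 2 (1.00 log units; beyond the scatter), in which cyclohexyl took the place of isopropyl on an amide-type nitrogen. Compound 3 `CCCS(=O)(=O)N1CCN(c2ccc(OCC3CCN(C(=O)c4ccco4)CC3)cn2)CC1` differs from compound 2 by furan-2-yl in place of cyclohexylamino on a carbonyl carbon; read one bond further out, cyclohexylcarbamoyl becomes (furan-2-yl)carbonyl. For the measured compounds named here, no measured step covers this exact exchange, but the cyclohexyl group leaves, and a smaller ring enters on the carbonyl carbon. A fall in the number is expected for the step of an at least 3.3-fold lower number from compound 2 to compound 3 (0.52 log units; beyond the scatter) because the step of an at least 10-fold higher number from compound 1 to compound 2 (1.00 log units; beyond the scatter) showed the cyclohexyl arriving together with a loss of potency. Compound 3 is therefore estimated at 3000 nM, with a likely range from 500 nM to 20000 nM.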

Compound 3, half-maximal effective concentration: 2000 nM
Compound 3: the middle estimate sits 1.5-fold (0.18 log units) above what was measured; the range from low to high includes it.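

In this assay, the carbonyl carbon on the ring nitrogen no longer needs an amino group to give a measurable response, and a ring at this place is not in itself a dead end. Setting furan-2-yl in place of isopropylamino gives a 2.0-fold higher number from compound 1 to compound 3 (0.30 log units; within the scatter), and setting it in place of cyclohexylamino gives an at least 5.0-fold lower number from compound 2 to compound 3 (0.69 log units; beyond the scatter). The starting point of that second step is a limit of the assay and not a number, as compound 2 shows: the limit of > 10000 nM in this assay, at which 1 of the 3 values shown sits.

The amino nitrogen left and the aromatic ring entered in a single exchange, so the compounds shown do not tell these two changes apart. On these data alone, whether the furan oxygen matters also stays open, and a phenyl or thiophene ring on the same carbonyl carbon would help to settle that.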